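The compounds below may be only part of what the source reports. "The series", "measured", "known", "first", "only" and "open" are said of these compounds alone.

For the measured compounds named here, compound 2 `COc1ccc(CN2C(=O)/C(=C/c3cc(C)n(-c4ccc(O)c(C(=O)O)c4)c3C)SC2=S)cc1` gives 75300 nM in an ADME assay on MT2 cells (Homo sapiens) for cytotoxicity, read by XTT assay, with a stated time of 4 days (a higher number here means that more compound is tolerated, a lower number that less compound is tolerated), the higher of the two numbers so far, with compound 1 `Cc1cc(/C=C2\SC(=S)N(Cc3ccc(C(F)(F)F)cc3)C2=O)c(C)n1-c1ccc(O)c(C(=O)O)c1` nearest at 45900 nM and a 1.6-fold higher number from compound 1 to compound 2 (0.21 log units; within the scatter). Compound 3 `COC(=O)c1cccc(CN2C(=O)/C(=C/c3cc(C)n(-c4ccc(O)c(C(=O)O)c4)c3C)SC2=S)c1` differs from compound 2 by 3-(methoxycarbonyl)phenyl in place of 4-methoxyphenyl on a saturated chain carbon bound to an amide-type nitrogen in a ring. Going by the values given here, the only measured step in this assay also exchanged a group on that same aromatic ring and stayed within the scatter, so nothing beyond the scatter is expected here either; the step to compound 3 is estimated as a 1.1-fold lower number from compound 2 to compound 3 (0.03 log units; within the scatter). Compound 3 is therefore expected to give about 70000 nM in this assay, within a range of 30000 nM to 160000 nM.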

Compound 3, half-maximal cytotoxic concentration: 38500 nM
Estimate against measurement, compound 3: 1.8-fold (0.26 log units) above; the measured number falls inside the stated range.
By their numbers in this assay, from the lowest: compounds 3, 1 and 2 (each within the scatter of the next).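

In this assay this position, the saturated chain carbon bound to an amide-type nitrogen in a ring, also accepts 3-(methoxycarbonyl)phenyl with only a 2.0-fold lower number from compound 2 to compound 3 (0.29 log units; within the scatter) and a 1.2-fold lower number from compound 1 to compound 3 (0.08 log units; within the scatter). Both steps lie within the scatter, so the three aromatic groups at this position are not told apart by this read-out. No evidence bears on these numbers. Open, going by these compounds, is whether an amine, a carboxylic acid or a longer alkyl chain at this position would give a step beyond the scatter.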